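The source may hold more compounds than are shown below. What is called first, only, known or untested is meant among the compounds shown, and "the series" means these compounds.

Compound 1 `C[S+]([O-])c1ccc(CSc2nc(-c3ccc(Cl)cc3)c(-c3ccncc3)[nH]2)cc1`: 320 nM
Compound 2 `CSc1ccc(CSc2nc(-c3ccc(Br)cc3)c(-c3ccncc3)[nH]2)cc1`: 2400 nM

Both values come from a functional assay (Homo sapiens) for inhibition; on this read-out lower numbers stand for stronger inhibition and higher numbers for weaker inhibition. Compound 2 has the higher of the two numbers, and the gap down to compound 1 lies beyond the scatter. Compound 3 `C[S+]([O-])c1ccc(CSc2nc(-c3ccc(Br)cc3)c(-c3ccncc3)[nH]2)cc1` differs from compound 2 in one place: a group of 3 heavy atoms (1 carbon, 1 oxygen, 1 sulfur; no ring) in place of a group of 2 heavy atoms (1 carbon, 1 sulfur; no ring), on an aromatic carbon. The change sits on an aromatic carbon of a six-membered aromatic ring of carbon only, para to a large group. For the measured compounds named here, the entering group also occurs in compound 1, but compound 1 and compound 2 differ in more than one place, and no measured pair isolates this change. The expectation therefore rests only on compound 1 at 320 nM: a drop beyond the scatter in this assay, towards that value. The expected change is a 6.0-fold lower number from compound 2 to compound 3 (0.78 log units; beyond the scatter). The estimate for compound 3 is 400 nM, with an expected range of 130 nM to 1200 nM.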

Compound 3, half-maximal inhibitory concentration: 820 nM
The estimate for compound 3 lay 2.1-fold (0.31 log units) below the measured number, and the stated range covers the measured number.
By their numbers in this assay, from the lowest: compound 1; then compound 3; then compound 2.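

In this assay, with bromo held constant, the oxygen-bearing sulfur group in place of methylsulfanyl on the aromatic carbon gives a 2.9-fold lower number from compound 2 to compound 3 (0.47 log units; beyond the scatter), so this position responds to the change on its own. With that sulfur group held constant, bromo in place of chloro gives a 2.6-fold higher number from compound 1 to compound 3 (0.41 log units; beyond the scatter), so the gap between compound 1 and compound 2 spans two changes that each have a measurable step. Nothing at hand explains either step.

Whether the sulfur step is the same size on the chloro compounds remains open, as the compounds shown contain no chloro partner carrying methylsulfanyl. Also open, as far as these compounds go, is how this position responds to a methylsulfonyl group, with a second oxygen on sulfur, or to a nitrile.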